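Urea series: 3,4-dimethylphenyl replacing 4-ethylphenyl

A few compounds are considered here, and "the series" means these few. Any claim that something is new, unique, unknown or untested is made for them only; others in the source may bear on it.

Measured so far:
- compound 1, `CCc1ccc(Nc2cc(NC(=O)Nc3c(Cl)cccc3Cl)ncn2)cc1`: 70.1%
- compound 2, `CCc1cccc(Nc2cc(NC(=O)Nc3cc(OC)cc(OC)c3)ncn2)c1`: 82.1%
- compound 3, `COc1ccc(C(F)(F)F)cc1Nc1cc(NC(=O)Nc2c(Cl)cccc2Cl)ncn1`: 89%

The read-out is a functional assay on PC-9 cells (Homo sapiens) for inhibition, read by MTT assay, with a stated time of 48 h, tested at 10 uM; on this read-out higher numbers stand for more inhibition at the one concentration tested (going by the name of the read-out) and lower numbers for less inhibition. Compound 1 stands lowest of the three numbers in this assay, with 70.1%. Compound 2 sits closest to it at 82.1%, a gap beyond the scatter; compound 3 is furthest at 89%, also beyond the scatter. Among the compounds with values here, compounds 2 and 3 differ from compound 1 in more than one place, so no single step among measured compounds can be read from them; only the bare values stand.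

The unmeasured compound is compound 4, `Cc1ccc(Nc2cc(NC(=O)Nc3c(Cl)cccc3Cl)ncn2)cc1C`. It differs from compound 1 in one place: 3,4-dimethylphenyl in place of 4-ethylphenyl on a nitrogen on an aromatic ring. The two share the same atoms, joined differently, and the change keeps the ring, the count of heavy atoms, and the absence of donors and acceptors unchanged.

Within the data shown here, no measured pair tracks this kind of change. Given how small the rearrangement is, the step from compound 1 to compound 4 in this assay is expected to be modest, estimated as a number 2.1 percentage points lower from compound 1 to compound 4 (within the scatter), likely within the scatter in either direction. Compound 4 is accordingly estimated at 68% in this assay, with an expected range from 50% to 84%.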

Compound 4, a percentage reported as inhibition, at one concentration (the size of the read-out at that concentration, not a potency): 92.1%
Compound 4: middle estimate off by 24.1 percentage points, on the low side; the whole stated range lies below it.
By their numbers in this assay, from the lowest: compound 1; then compounds 2, 3 and 4 (each within the scatter of the next).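

In this assay, the aryl group on the nitrogen turns out to be a position where the arrangement of the same carbons matters: a number 22 percentage points higher from compound 1 to compound 4 (beyond the scatter), a step beyond the scatter, with the aromatic ring and the heavy-atom count of the group unchanged. Within the data shown here, the earlier compounds differed from compound 1 in more than one place, so this is the first change that can be assigned to this position alone, with the rest of the structure held fixed. No measurement at hand accounts for the size of this step.

On these data alone, this single pair cannot separate the effect of adding a substituent at the second ring position from that of shortening ethyl to methyl, so it remains open whether both methyl groups are needed or either alone would give the same read-out. Also open, as far as these compounds go, is how the position responds to groups of another kind on this ring, such as a propyl chain, a morpholine or a carboxylic acid, and whether the step holds when the other aryl group of the urea is changed.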